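Series notes: amide variation and aryl replacement at the core

The compounds below may be only part of what the source reports. "The series", "measured", "known", "first", "only" and "open" are said of these compounds alone.

Measured so far in a functional assay on KYSE-410 cells (Homo sapiens) for antiproliferative activity, read by MTT assay, with a stated time of 72 h; on this read-out higher numbers stand for weaker inhibition and lower numbers for stronger inhibition:
Compound 1 `O=C(Nc1cccc(F)c1)c1cc(=O)[nH]c2cc(Br)ccc12` gives 7300 nM.
Compound 2 `COc1cccc(NC(=O)c2cc(=O)[nH]c3cc(Br)ccc23)c1` gives > 20000 nM, which is a limit of this assay, not a number.
Compound 3 `O=C(Nc1cc(F)cc(F)c1)c1cc(=O)[nH]c2cc(Br)ccc12` gives 11200 nM.

Compound 1 holds the lowest of the two numbers shown; compound 3 sits nearest, with a 1.5-fold higher number from compound 1 to compound 3 (0.19 log units; within the scatter), and an at least 2.7-fold higher number from compound 1 to compound 2 (0.43 log units; beyond the scatter) runs into the limit (the limit of > 20000 nM in this assay, at which 1 of the 3 values shown sits).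

Compound 4 `Cc1cc(-c2ccc3c(C(=O)Nc4cccc(F)c4)cc(=O)[nH]c3c2)c(C)cc1F` differs from compound 1 at the core: 4-fluoro-2,5-dimethylphenyl in place of bromo on an aromatic carbon. Within the data shown here, both measured steps alter the amide-side aromatic group; neither touches the core, so no measured step bears on this change, and its direction in this assay is open. The estimate for compound 4 is therefore 3000 nM, spanning 400 nM to 20000 nM, and the expected step is a 2.4-fold lower number from compound 1 to compound 4 (0.39 log units; beyond the scatter).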

Compound 4, half-maximal inhibitory concentration: > 20000 nM
Compound 4: no number, only a limit (the forecaster's own chance of this, stated with the estimate: 15%); middle value at least 6.6-fold (0.82 log units) away from the limit.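

In this assay compound 4 gives > 20000 nM, which is a limit and not a number. Placing 4-fluoro-2,5-dimethylphenyl on the core in place of bromo gives an at least 2.7-fold higher number from compound 1 to compound 4 (0.43 log units; beyond the scatter), so the read-out responds at this position, which the earlier steps left untouched, and this aryl group does not retain the activity of compound 1. A change at the core, like one on the amide side, now ends at the limit: the limit of > 20000 nM in this assay, at which 2 of the 4 values shown sit.

On these data alone, whether the loss belongs to this particular aryl group or to any aryl group here remains open. Also open, as far as these compounds go, is how chloro, an amine or a carboxylic acid would behave in place of bromo.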